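This account rests on a few compounds, and the source may have more. Where it says the series, first, only, none or still open, it means among the compounds named here.

Measured compounds:
- compound 1 `C=CC1=C(C(=O)NCc2ccccc2)C(c2ccc(OC)cc2)OC1`: in a functional assay on A549 cells (Homo sapiens) for cytotoxicity, read by MTT assay, with a stated time of 24 h (a higher number here means a weaker inhibitor, a lower number a stronger inhibitor), compound 1 gives > 100000 nM, a limit of the assay.
- compound 2 `C=CC1=C(C(=O)Nc2ccccc2OC)C(c2ccc(F)cc2)OC1`: in this assay compound 2 gives > 100000 nM, a limit of the assay.
- compound 3 `C=CC1=C(C(=O)NCC(C)C)C(c2ccc(OC)cc2)OC1`: in this assay compound 3 gives > 100000 nM, a limit of the assay.

Compound 3 therefore stands only at a limit, as do the other two members of the series; all three values sit at the limit of > 100000 nM in this assay, at which 3 of the 3 values shown sit. Within the data shown here, the one single-point step that can be read within the measured set, a step that the two limits leave unreadable from compound 1 to compound 3, is not resolved, since both ends are limits.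

The next compound, compound 4 `C=CC1=C(C(=O)Nc2ccccc2OC)C(c2ccc(OC)cc2)OC1`, differs from compound 3 by 2-methoxyphenyl in place of isobutyl on an amide-type nitrogen. Among the measured compounds shown here, no measured step bears directly on this change. Compound 2 carries the same amide substituent as compound 4 with a different aryl group on the shared core, and its value is also a limit. With every value in the series at the limit, no direction or size of step beyond the scatter can be supported in this assay.

The estimate for compound 4 is accordingly expected to remain at or beyond the limit, with a step that the limit leaves unreadable from compound 3 to compound 4 that is not expected to exceed the scatter; compound 4 is estimated at 200000 nM, within 60000 nM to 1000000 nM.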

Compound 4, half-maximal inhibitory concentration: > 100000 nM
Compound 4: only a limit was reported; the forecaster's own chance of this, stated with the estimate: 85%; the middle value lies beyond the limit too.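

In this assay compound 4 gives > 100000 nM and this is a limit. No step from compound 1, compound 2 or compound 3 to compound 4 can be read: the limit of > 100000 nM in this assay, at which 4 of the 4 values shown sit.

Left open is whether any change to the amide substituent or the aryl group on the shared core gives a number rather than a limit in this assay at all.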